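Deacetylation of the oxime acetate: compound 3 to compound 4

A few compounds are considered here, and "the series" means these few. Any claim that something is new, unique, unknown or untested is made for them only; others in the source may bear on it.

Measured compounds in an ADME assay on DU-145 cells (Homo sapiens) for cytotoxicity, read by MTT assay, with a stated time of 72 h; on this read-out higher numbers stand for weaker inhibition and lower numbers for stronger inhibition:
compound 1 `COc1cc(C2=C(c3cc(C)c(OC)c(C)c3)C(O)CC2=O)cc(OC)c1OC` gives > 100 ug/mL, a limit of the assay and not a number.
compound 2 `COc1ccc(C2=C(c3cc(OC)c(OC)c(OC)c3)C(=O)C(OC(C)=O)C2)cc1O` gives > 100 ug/mL, also only a limit.
compound 3 `CC(=O)OC1C/C(=N/O)C(c2ccccc2)=C1c1ccccc1` gives > 100 ug/mL, again a limit.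

Compound 3 stands where every measured compound of the series stands: no number is known for it, only (the limit of > 100 ug/mL in this assay, at which 3 of the 3 values shown sit). Nothing in the data separates compound 3 from compound 1 or compound 2, as all three values are limits.

Compound 4 `O/N=C1/CC(O)C(c2ccccc2)=C1c1ccccc1` is the unmeasured partner of compound 3. The difference between them is hydrogen in place of acetyl on an oxygen on a saturated carbon.

Among the measured compounds shown here, with no measured step anywhere and all values sitting at the limit, there is no basis for expecting a change beyond the scatter in this assay in either direction. The step from compound 3 to compound 4 is therefore estimated as a number no higher from compound 3 to compound 4 (the limit leaves the size open), that is, none beyond the scatter. Compound 4 is expected to give about 100 ug/mL, most likely reported again as a limit, within a range of 50 ug/mL to 200 ug/mL.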

Compound 4, half-maximal inhibitory concentration: > 100 ug/mL
Compound 4: a limit, no number; the forecaster's own chance of this, stated with the estimate: 80%; the middle value sits exactly at the limit.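

The step from compound 3 to compound 4, acetoxy to hydroxy, cannot be read in this assay, where both values are limits and not numbers: the limit of > 100 ug/mL in this assay, at which 4 of the 4 values shown sit. The compounds shown leave open whether this change has any effect in this assay, and how far any of them lies past the limit.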